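Swapping 2-nitrophenyl for 2,5-difluorophenyl at the assay limit

A few compounds are considered here, and "the series" means these few. Any claim that something is new, unique, unknown or untested is made for them only; others in the source may bear on it.

In a functional assay on Jurkat cells (Homo sapiens) (on this read-out lower numbers stand for stronger inhibition and higher numbers for weaker inhibition), compound 1 (`CC(C)[C@H](NC(=O)COc1cccc2ccccc12)C(=O)N[C@@H](CC(=O)O)C(=O)COc1ccc2ccccc2c1`) gives > 100000 nM as a limit only. Compound 2 (`CC(C)[C@H](NC(=O)COc1cccc2ccccc12)C(=O)N[C@@H](CC(=O)O)C(=O)COc1cccc(C(F)(F)F)c1`) gives > 100000 nM as a limit too. Compound 3 (`CC(C)[C@H](NC(=O)COc1cccc2ccccc12)C(=O)N[C@@H](CC(=O)O)C(=O)COc1ccccc1[N+](=O)[O-]`) gives > 100000 nM as a limit as well. Compound 3 therefore stands at the limit of > 100000 nM in this assay, at which 3 of the 3 values shown sit, and has no number of its own. Compound 4 (`CC(C)[C@H](NC(=O)COc1cccc2ccccc12)C(=O)N[C@@H](CC(=O)O)C(=O)COc1cc(F)ccc1F`) carries 2,5-difluorophenyl in place of 2-nitrophenyl on an oxygen on a saturated carbon. The measured changes at this place are a step that the two limits leave unreadable from compound 1 to compound 3 and a step that the two limits leave unreadable from compound 2 to compound 3 and also a step that the two limits leave unreadable from compound 1 to compound 2 and none of them has a size to carry over. The expected step, only loosely held, is an at least 1.6-fold lower number from compound 3 to compound 4 (0.22 log units; that floor lies within the scatter) and any readable value would lie on the stronger side of the limit. Compound 4 is estimated at 60000 nM with a range of 5000 nM to 100000 nM in this assay and may again read only as a limit.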

Compound 4, half-maximal inhibitory concentration: > 100000 nM
Compound 4: a limit, no number; the forecaster's own chance of this, stated with the estimate: 60%; middle value at least 1.6-fold (0.22 log units) away from the limit.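

No step can be read from compound 4 to compound 1, compound 2 or compound 3, because all of them stand at one limit: the limit of > 100000 nM in this assay, at which 4 of the 4 values shown sit.

The compounds shown leave open whether any group on this oxygen gives a readable value in this assay.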